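Growth inhibition notes: compound 2 to compound 4

A few compounds are considered here, and "the series" means these few. Any claim that something is new, unique, unknown or untested is made for them only; others in the source may bear on it.

Measured in a functional assay on BaF3 cells (Mus musculus) for inhibition, read by MTT assay, with a stated time of 3 days (on this read-out lower numbers stand for stronger inhibition of growth and higher numbers for weaker inhibition of growth), all as limits:
compound 1 `O=C(Nc1ccc(Nc2ncnc3c2OCCN3)cc1)Nc1ccc(Cl)c(C(F)(F)F)c1` limit > 10000 nM
compound 2 `Cc1ccc(F)c(NC(=O)Nc2ccc(Nc3ncnc4c3OCCN4)cc2)c1` limit > 10000 nM
compound 3 `O=C(Nc1ccc(Nc2ncnc3c2OCCN3)cc1)Nc1cccc(-c2ccccc2)c1` limit > 10000 nM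

Compound 2 gives only a limit and no number, and it stands with the other two measured compounds at the limit of > 10000 nM in this assay, at which 3 of the 3 values shown sit. For the measured compounds named here, no measured step between compounds is available to size a structural change.

Compound 4 `CC(C)(C)c1csc(NC(=O)Nc2ccc(Nc3ncnc4c3OCCN4)cc2)n1` is still unmeasured. Its difference from compound 2 is 4-(tert-butyl)-1,3-thiazol-2-yl in place of 2-fluoro-5-methylphenyl on an amide-type nitrogen, with 4-(tert-butyl)-1,3-thiazol-2-yl in place of 2-fluoro-5-methylphenyl on an amide-type nitrogen.

The expectation rests only on (the limit of > 10000 nM in this assay, at which 3 of the 3 values shown sit), shared by compound 1, compound 2 and compound 3, so it carries wide uncertainty. In this assay no change beyond the scatter is expected, and the estimated step is a number no higher from compound 2 to compound 4 (the limit leaves the size open). Another result reported only as a limit is the likeliest outcome. The estimate for compound 4 is 10000 nM, with an expected range of 2000 nM to 20000 nM.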

Compound 4, concentration for 50% growth inhibition: > 10000 nM
Compound 4 was reported as a limit (the forecaster's own chance of this, stated with the estimate: 70%); the middle value lies on the limit itself.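

Compound 2 and compound 4 are both reported only as limits in this assay, so no step can be read between them: the limit of > 10000 nM in this assay, at which 4 of the 4 values shown sit.

The compounds shown leave open whether any group on the amide-type nitrogen gives a readable number in this assay.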